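The source may hold more compounds than are shown below. What is called first, only, known or untested is meant among the compounds shown, and "the series" means these compounds.

In a functional assay on DLD-1 cells (Homo sapiens) for antiproliferative activity, read by CellTiter-Glo, with a stated time of 72 h (a higher number here means a weaker inhibitor, a lower number a stronger inhibitor), compound 1 `CC1CCN(C2CCN(S(=O)(=O)c3ccc(C#N)cc3)CC2)CC1` gives 2800 nM, the second highest of three numbers, though within the scatter of compound 2 `CC1CCN(C2CCN(S(=O)(=O)c3cccc(N)c3)CC2)CC1` at 3400 nM. Compound 3 `CC1CCN(C2CCN(S(=O)(=O)c3ccccc3Br)CC2)CC1` gives 3 nM, far from both: a 930-fold lower number from compound 1 to compound 3 (2.97 log units; beyond the scatter), and a 1100-fold lower number from compound 2 to compound 3 (3.05 log units; beyond the scatter).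

Compound 4 `CC1CCN(C2CCN(S(=O)(=O)c3ccc(OCc4ccccc4)cc3)CC2)CC1` changes compound 1 by benzyloxy in place of cyano on an aromatic carbon. The benzyloxy sits on an aromatic carbon, para to a large group.

Both large steps end at the 2-bromophenyl of compound 3, which compound 4 does not carry, so neither is expected to carry over. The closer precedent is a 1.2-fold higher number from compound 1 to compound 2 (0.08 log units; within the scatter), where changing the aryl group on the sulfonyl sulfur moved nothing. Among the compounds with values here, no measured compound carries a benzyloxy, so the data say little about a group of this size, and the range stays wide.

No step beyond the scatter is expected, and the estimated step is a 1.4-fold lower number from compound 1 to compound 4 (0.15 log units; within the scatter). The value expected for compound 4 is 2000 nM, with an estimated range of 250 nM to 9000 nM.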

Compound 4, half-maximal inhibitory concentration: 385 nM
For compound 4 the middle estimate is 5.2-fold (0.72 log units) above the measured one, and the stated range covers the measured number.
By their numbers in this assay, from the lowest: compound 3; then compound 4; then compounds 1 and 2 (each within the scatter of the next).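

At this place, on an aromatic carbon para to a large group, benzyloxy with its 8 heavy atoms and six-membered aromatic ring is accepted in this assay in place of the 2-heavy-atom cyano, and the number falls: a 7.3-fold lower number from compound 1 to compound 4 (0.86 log units; beyond the scatter). Within the data shown here, until now, the only step among the aryl groups without a 2-bromophenyl was a 1.2-fold higher number from compound 1 to compound 2 (0.08 log units; within the scatter), so this is the first sign that the 4-substituted aryl series can move beyond the scatter. The gain remains well short of a 930-fold lower number from compound 1 to compound 3 (2.97 log units; beyond the scatter). Nothing shown bears on the reason for the change.

Open, as far as these compounds go, is which part of benzyloxy matters: a methoxy or a phenyl at this place would separate the oxygen from the added ring. Also open, from the compounds shown here alone, is how an amine or a carboxylic acid on the benzyl ring would read in this assay.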